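1-Methyl-1H-indazol-6-yl replaces 1-methyl-1H-indol-6-yl

This account rests on a few compounds, and the source may have more. Where it says the series, first, only, none or still open, it means among the compounds named here.

In a functional assay on MCF7 cells (Homo sapiens) for inhibition, read by CCK-8 assay, with a stated time of 48 h (a lower number here means a stronger inhibitor, a higher number a weaker inhibitor), compound 1 (`COc1cc(-c2ccnc3cc(-c4ccccc4)nn23)cc(OC)c1OC`) gives 254 nM, compound 2 (`COc1cc(-c2ccnc3cc(-c4ccc(N(C)C)cc4)nn23)cc(OC)c1OC`) gives 44 nM and compound 3 (`COc1cc(-c2ccnc3cc(-c4ccc5ccn(C)c5c4)nn23)cc(OC)c1OC`) gives 74 nM. Compound 3 therefore stands apart from compound 1 but cannot be separated from compound 2. Compound 4 (`COc1cc(-c2ccnc3cc(-c4ccc5cnn(C)c5c4)nn23)cc(OC)c1OC`) carries 1-methyl-1H-indazol-6-yl in place of 1-methyl-1H-indol-6-yl on an aromatic carbon. Going by the values given here, no measured step makes this exact exchange. The nearest evidence comes from two exchanges of the whole group at this place: a 3.4-fold lower number from compound 1 to compound 3 (0.54 log units; beyond the scatter), and a 1.7-fold higher number from compound 2 to compound 3 (0.23 log units; within the scatter). No step beyond the scatter is therefore expected in this assay, only the estimated 1.2-fold higher number from compound 3 to compound 4 (0.09 log units; within the scatter). For compound 4 the estimated value is 90 nM, with an expected range of 30 nM to 270 nM.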

Compound 4, half-maximal inhibitory concentration: 279 nM
Compound 4: the middle estimate sits 3.1-fold (0.49 log units) below what was measured, and the stated range ends below it.
By their numbers in this assay, from the lowest: compounds 2 and 3 (each within the scatter of the next); then compounds 1 and 4 (each within the scatter of the next).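

In this assay this position proves sensitive to a small edit: with the heavy-atom count unchanged, a second hetero atom in the five-membered aromatic ring gives a 3.8-fold higher number from compound 3 to compound 4 (0.58 log units; beyond the scatter). The same compound also falls well short of the dimethylamino compound, with a 6.3-fold higher number from compound 2 to compound 4 (0.80 log units; beyond the scatter), and the comparison with plain phenyl gives a 1.1-fold higher number from compound 1 to compound 4 (0.04 log units; within the scatter), so the benefit of the indole group is not shared by its indazole relative. Nothing measured here accounts for this loss. On these data alone, whether a 1-methyl-1H-benzimidazol-6-yl group or a phenyl bearing a morpholine would keep the potency of compound 2 remains open.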